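The source may report more compounds than this note shows. Statements on the series, on what has been measured and on what is new or still open speak of the compounds shown alone.

Working notes on the shared core of compound 1 `O=C(Nc1nnc(-c2cccc(O)c2O)s1)c1ccccc1` in an ADME assay on MRC5 cells (Homo sapiens) for cytotoxicity, read by MTT assay, with a stated time of 72 h; a lower number here means a stronger inhibitor, a higher number a weaker inhibitor. Compound 1 gives 23200 nM in this assay. Going by the values given here, compound 2 `O=C(Nc1nnc(-c2cccc(O)c2O)s1)C1CCCCC1` gives 70300 nM in this assay, and the step of a 3.0-fold higher number from compound 1 to compound 2 (0.48 log units; beyond the scatter) is the only comparison available so far. On the two numbers in hand, compound 2 therefore carries the higher number, and compound 1 the lower.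

The next member is compound 3 `O=C(COc1ccccc1)Nc1nnc(-c2cccc(O)c2O)s1`. The change from compound 2 is phenoxymethyl in place of cyclohexyl on a carbonyl carbon. Among the compounds with values here, the only measured step that bears on it is the one between compound 1 and compound 2, where a six-membered aromatic ring of carbon only on the carbonyl carbon went with the lower number and cyclohexyl with the higher; that step was modest and beyond the scatter. Phenoxymethyl brings back a six-membered aromatic ring of carbon only, now with one hydrogen-bond acceptor, so a step back toward the number of compound 1 is expected, of roughly the size seen before, with wide uncertainty. For compound 3 the expected step is a 2.0-fold lower number from compound 2 to compound 3 (0.30 log units; within the scatter). The estimate for compound 3 in this assay is 35000 nM, within a range of 12000 nM to 100000 nM.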

Compound 3, half-maximal inhibitory concentration: 33900 nM
Compound 3: middle estimate off by 1.0-fold (0.01 log units), on the high side; the range from low to high includes it.
By their numbers in this assay, from the lowest: compounds 1 and 3 (each within the scatter of the next); then compound 2.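

In this assay, phenoxymethyl in place of cyclohexyl on a carbonyl carbon gives a 2.1-fold lower number from compound 2 to compound 3 (0.32 log units; beyond the scatter), so a second group carrying a six-membered aromatic ring of carbon only now goes with a lower number than cyclohexyl. Phenoxymethyl in place of phenyl gives a 1.5-fold higher number from compound 1 to compound 3 (0.16 log units; within the scatter), so this read-out does not separate the two groups, and the extra atoms of phenoxymethyl, its oxygen among them, bring no resolved change here. Across these three compounds, cyclohexyl alone stands apart from the two groups with an aromatic ring, none of the three goes against that, and nothing measured alongside these numbers accounts for it.

Three groups on one carbonyl carbon cannot show whether the aromatic ring itself or some other difference from cyclohexyl goes with the lower numbers, and a longer chain between the carbonyl and the ring, or an amine or a carboxylic acid on that ring, would test this further. From the compounds shown here alone, the rest of the shared core is the same in all three compounds, so what it contributes to the numbers in this assay remains open.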